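Cytotoxicity notes on the amino side chain

The compounds below may be only part of what the source reports. "The series", "measured", "known", "first", "only" and "open" are said of these compounds alone.

Values in an ADME assay on Vero cells (Chlorocebus sabaeus) for cytotoxicity, read by CellTiter-Glo, with a stated time of 72 h (on this read-out lower numbers stand for higher toxicity in this test and higher numbers for lower toxicity in this test), follow.
- compound 1 `CCNc1n[n+]([O-])c2cc(Cl)ccc2[n+]1[O-]` gives 2.6 ug/mL
- compound 2 `[O-][n+]1nc(NC2CC2)[n+]([O-])c2ccc(Cl)cc21` gives 1.3 ug/mL

Set against compound 1 in this assay compound 2 stands at 1.3 ug/mL and the two values cannot be ordered. Compound 3 `COCC(C)Nc1n[n+]([O-])c2cc(Cl)ccc2[n+]1[O-]` has 1-(methoxymethyl)ethyl in place of cyclopropyl on a nitrogen on an aromatic ring, a change counted as 1-(methoxymethyl)ethyl in place of cyclopropyl on a nitrogen on an aromatic ring and not yet tested. Within the data shown here, one measured step bears on this place, a 2.0-fold lower number from compound 1 to compound 2 (0.30 log units; within the scatter) and it is a thin guide, since it covers only ethyl and cyclopropyl. On that step from compound 1 to compound 2 no clear direction is expected. The expected step is a 1.7-fold higher number from compound 2 to compound 3 (0.23 log units; within the scatter) and no move beyond the scatter is expected. For compound 3 the estimated value is 2.2 ug/mL with an expected range from 0.9 ug/mL to 5.5 ug/mL in this read-out.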

Compound 3, half-maximal cytotoxic concentration: 2.6 ug/mL
The estimate for compound 3 lay 1.2-fold (0.07 log units) below the measured number, within the range that was stated.
By their numbers in this assay, from the lowest: compounds 2, 1 and 3 (each within the scatter of the next).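

In this assay, 1-(methoxymethyl)ethyl in place of cyclopropyl on this nitrogen gives a 2.0-fold higher number from compound 2 to compound 3 (0.30 log units; within the scatter), so a group with no ring and one hydrogen-bond acceptor leaves the read-out within the scatter. Methoxymethyl in place of hydrogen on the saturated chain carbon gives no change at the digits printed from compound 1 to compound 3 (within the scatter), and this extends the flat picture from ethyl and cyclopropyl to a side chain containing oxygen. No measurement at hand accounts for this flat picture.

On these data alone, whether a basic amine, a carboxylic acid or a longer chain on this nitrogen would move the number beyond the scatter remains open. The compounds shown also leave open whether the same flat picture would hold with a group other than the chlorine of the shared core.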